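The source may hold more compounds than are shown below. What is called first, only, known or untested is meant among the compounds shown, and "the series" means these compounds.

Measured so far:
Compound 1 `CC[C@@H]1C(=O)N(C)c2cnc(-n3ccc4cc(F)ccc43)nc2N1C1CCCC1` — 21200 nM
Compound 2 `CC[C@@H]1C(=O)N(C)c2cnc(Nc3ccc(S(=O)(=O)NCCO)cc3)nc2N1C1CCCC1` — 546 nM

In a functional assay on K562 cells (Homo sapiens) for antiproliferative activity, read by CCK-8 assay, with a stated time of 72 h (a lower number here means a stronger inhibitor of growth, a higher number a weaker inhibitor of growth), compound 2 gives 546 nM, the lowest of the two numbers. Compound 1 gives 21200 nM, a higher number that lies beyond the usual scatter. Compound 3 `CCCCNS(=O)(=O)c1ccc(Nc2ncc3c(n2)N(C2CCCC2)[C@H](CC)C(=O)N3C)cc1` is not yet measured and differs from compound 2 in one place: ethyl in place of hydroxy on a saturated chain carbon, two bonds along the chain from a sulfonamide nitrogen. Within the data shown here, no pair of measured compounds shows this change, so nothing here sets its size. Compound 3 is expected to give 600 nM in this assay, with a range from 200 nM to 1800 nM. The step of a 1.1-fold higher number from compound 2 to compound 3 (0.04 log units; within the scatter) is expected to stay within the scatter.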

Compound 3, concentration for 50% growth inhibition: 412 nM
Compound 3: middle estimate off by 1.5-fold (0.16 log units), on the high side, within the range that was stated.
By their numbers in this assay, from the lowest: compounds 3 and 2 (each within the scatter of the next); then compound 1.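

In this assay the swap of 2-hydroxyethyl for butyl on the sulfonamide nitrogen gives a 1.3-fold lower number from compound 2 to compound 3 (0.12 log units; within the scatter) and so stays within the scatter. At this position, then, the hydroxy with its hydrogen-bond donor and acceptor can be replaced by an ethyl with neither, and growth inhibition stays at the same level. No measured evidence bears on why this is so. Still open, as far as these compounds go, is whether an amine or a carboxylic acid at the end of this chain, or a chain longer than butyl, would give a number beyond the scatter.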